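Swapping the Ring on the Side Chain of Compound 3

The source may report more compounds than this note shows. Statements on the series, on what has been measured and on what is new or still open speak of the compounds shown alone.

Measured so far:
- compound 1 `CC(C)C(c1ccc(-c2ccc3cccc(F)c3c2)[nH]c1=O)N1CCCCS1(=O)=O`: 122 nM
- compound 2 `CC(C)C(Nc1nnc[nH]1)c1ccc(-c2ccc3cccc(F)c3c2)[nH]c1=O`: 185 nM
- compound 3 `CC(C)C(Cc1noc(=O)[nH]1)c1ccc(-c2ccc3cccc(F)c3c2)[nH]c1=O`: 70 nM

All three were tested in a functional assay on CHO cells for antagonist activity at prostaglandin E2 receptor EP3 subtype (Homo sapiens), read by cAMP accumulation; a lower number here means a stronger inhibitor, a higher number a weaker inhibitor. Compound 3 gives the lowest of the three numbers. Its nearest neighbour is compound 1, with a 1.7-fold lower number from compound 1 to compound 3 (0.24 log units; within the scatter), a step that lies within the scatter. The gap to compound 2 is larger: a 2.6-fold lower number from compound 2 to compound 3 (0.42 log units; beyond the scatter), a modest step beyond the scatter.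

Compound 4 is `CC(C)C(c1ccc(-c2ccc3cccc(F)c3c2)[nH]c1=O)N1CCNC1=O`. Its change from compound 3 is a group of 6 heavy atoms (3 carbon, 2 nitrogen, 1 oxygen; one five-membered non-aromatic ring with 2 hetero atoms) in place of a group of 7 heavy atoms (3 carbon, 2 nitrogen, 2 oxygen; one five-membered aromatic ring with 3 hetero atoms), on a saturated chain carbon bound to an aromatic carbon and a saturated chain carbon. The side chain thus carries a ring again, now a non-aromatic one bound through nitrogen, as in compound 1 and compound 2.

Within the data shown here, the steps that bear on this are the earlier ring swaps at the same position: a 1.7-fold lower number from compound 1 to compound 3 (0.24 log units; within the scatter) and a 2.6-fold lower number from compound 2 to compound 3 (0.42 log units; beyond the scatter). Exchanging one small ring for another at this carbon has so far moved the number only a little, and in both cases the aromatic ring of compound 3 gave the lower number. For compound 4 a small rise is therefore expected, a 1.9-fold higher number from compound 3 to compound 4 (0.27 log units; within the scatter), probably within or just beyond the scatter. The estimate for compound 4 in this assay is 130 nM, with a range from 50 nM to 350 nM.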

Compound 4, half-maximal inhibitory concentration: 28 nM
Compound 4: middle estimate off by 4.6-fold (0.67 log units), on the high side; the measured number lies below the stated range.
By their numbers in this assay, from the lowest: compound 4; then compounds 3, 1 and 2 (each within the scatter of the next, the first and the last beyond it).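

The 2-oxoimidazolidin-1-yl ring gives the lowest number yet on this saturated chain carbon, with a 2.5-fold lower number from compound 3 to compound 4 (0.40 log units; beyond the scatter), so an aromatic ring is not needed here for a low number, and this non-aromatic ring does better than the aromatic ring of compound 3. A non-aromatic ring is not enough by itself, however: compound 1 also carries one, bound through nitrogen, and the change still gives a 4.4-fold lower number from compound 1 to compound 4 (0.64 log units; beyond the scatter), while replacing the (4H-1,2,4-triazol-3-yl)amino group gives the largest step at this carbon so far, a 6.6-fold lower number from compound 2 to compound 4 (0.82 log units; beyond the scatter). These steps show that the choice of ring at this carbon can matter more than the first three compounds suggested, but nothing measured here accounts for the gain.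

Still open, from the compounds shown here alone, is whether a pyrrolidin-2-one, the same ring with a carbon in place of its second nitrogen, would keep the number this low. Also open, going by these compounds, is whether the ring itself matters, or whether an open-chain urea or a six-membered cyclic urea would serve as well.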